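A few compounds are considered here, and "the series" means these few. Any claim that something is new, unique, unknown or untested is made for them only; others in the source may bear on it.

Compound 1 `COc1cc(/C=C/C(=O)/C=C/c2cc(OC)c(OC)c(OC)c2)ccc1OCc1cn(CCCCOc2cc(=O)oc3ccccc23)nn1` and compound 2 `COc1cc(/C=C/C(=O)/C=C/c2cccs2)ccc1OCc1cn(CCCCOc2cc(=O)oc3ccccc23)nn1` share one core and differ in a single place: thiophen-2-yl in place of 3,4,5-trimethoxyphenyl on a double-bonded chain carbon bound to a double-bonded chain carbon. In a functional assay on HCT-116 cells (Homo sapiens) for inhibition, read by sulforhodamine B assay, with a stated time of 48 h, tested at 50 uM (a higher number here means more inhibition of growth at the concentration tested, a lower number less inhibition of growth), compound 1 gives 63%, while compound 2 gives 41%, so the step runs a number 22 percentage points lower from compound 1 to compound 2 (beyond the scatter). Compound 3 `COc1cc(/C=C/C(=O)/C=C/c2cc(OC)c(OC)c(OC)c2)ccc1OCc1cn(CCCOc2cc(=O)oc3ccccc23)nn1` is built on a different core; the difference between the two cores is not broken down here. In this assay compound 3 gives 76%, the highest of the three values, with both other compounds lying beyond the scatter below it. Compound 4 `COc1cc(/C=C/C(=O)/C=C/c2cccs2)ccc1OCc1cn(CCCOc2cc(=O)oc3ccccc23)nn1` has not yet been measured. It stands to compound 3 exactly as compound 2 stands to compound 1, since the same change is made at the same place: thiophen-2-yl in place of 3,4,5-trimethoxyphenyl on a double-bonded chain carbon bound to a double-bonded chain carbon. Among the measured compounds shown here, the step from compound 3 to compound 4 is expected to be a number 22 percentage points lower from compound 3 to compound 4 (beyond the scatter), resting on the single earlier example of this change between compound 1 and compound 2. Compound 4 is therefore estimated to give about 54% in this assay, most likely between 42% and 66%.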

Compound 4, percent growth inhibition at one concentration: 58%
Compound 4: middle estimate off by 4 percentage points, on the low side, within the range that was stated.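

In this assay putting thiophen-2-yl in place of 3,4,5-trimethoxyphenyl gives a number 18 percentage points lower from compound 3 to compound 4 (beyond the scatter) and so repeats what was seen on the other core: the same change on two cores in this assay, a number 22 percentage points lower (beyond the scatter) from compound 1 to compound 2 and a number 18 percentage points lower (beyond the scatter) from compound 3 to compound 4, 4 percentage points apart, within the scatter of two such steps. In this series, the change therefore carried over from one core to the other with the same direction and a similar size. Among the compounds shown here, this rests on only two pairs tested at one concentration in one cell line, and it does not show why the number falls or whether the step would hold on any further core.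

The compounds shown leave open how other groups at this place would behave, such as furan-2-yl or a phenyl ring carrying an amine. They also leave open whether a longer chain would change the size of the step.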